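Oxetane to oxane swap on the sulfonamide nitrogen chain

The source may hold more compounds than are shown below. What is called first, only, known or untested is meant among the compounds shown, and "the series" means these compounds.

Compound 1 `CC1(C)C[C@@H](CN([C@H](CCC(F)(F)F)C(N)=O)S(=O)(=O)c2ccc(Cl)cc2)O1` gives 16.5 mL/min/kg in an in vitro ADME assay on microsomes from liver (Homo sapiens) for metabolic stability, read by HPLC; a higher number here means faster removal of the compound, a lower number slower removal. Compound 2 `CC1(C)CO[C@@H]1CN([C@H](CCC(F)(F)F)C(N)=O)S(=O)(=O)c1ccc(Cl)cc1` reaches only a limit of this assay, > 293 mL/min/kg. Compound 3 `CC1(C)CO[C@H]1CN([C@H](CCC(F)(F)F)C(N)=O)S(=O)(=O)c1ccc(Cl)cc1` gives 262 mL/min/kg. The step of a 16-fold higher number from compound 1 to compound 3 (1.20 log units; beyond the scatter) is large, and an at least 17-fold higher number from compound 1 to compound 2 (1.24 log units; beyond the scatter) is of the same kind. The pair an at least 1.1-fold lower number from compound 2 to compound 3 (0.04 log units; that floor lies within the scatter) lies within the scatter, which fits (the fact that compounds 2 and 3 differ only in the configuration as drawn). Among the numbers shown compound 3 stands highest, with compound 1 far below it as a 16-fold higher number from compound 1 to compound 3 (1.20 log units; beyond the scatter) shows; the value of compound 2 counts here only as the limit of > 293 mL/min/kg in this assay, at which 1 of the 3 values shown sits.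

Compound 4 `NC(=O)[C@@H](CCC(F)(F)F)N(CC1CCOCC1)S(=O)(=O)c1ccc(Cl)cc1` differs from compound 3 by oxan-4-yl in place of 3,3-dimethyloxetan-2-yl on a saturated chain carbon bound to a sulfonamide nitrogen. Both measured steps of size only replace 4,4-dimethyloxetan-2-yl by 3,3-dimethyloxetan-2-yl, so none of them covers the move to oxan-4-yl. The measured spread between compound 1 and compound 3 suggests the group at this place can move this assay strongly; a drop from compound 3 is expected, a 3.3-fold lower number from compound 3 to compound 4 (0.52 log units; beyond the scatter), but with wide uncertainty. Compound 4 is estimated at 80 mL/min/kg, in the range 25 mL/min/kg to 250 mL/min/kg.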

Compound 4, clearance: 114 mL/min/kg
For compound 4 the middle estimate is 1.4-fold (0.15 log units) below the measured one; the range from low to high includes it.
By their numbers in this assay, from the lowest: compound 1; then compound 4; then compound 3. At a limit, above all of these: compound 2.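

The oxan-4-yl ring of compound 4 gives an intermediate level in this assay, so this place on a saturated chain carbon bound to a sulfonamide nitrogen is not limited to the two extremes seen with the dimethyloxetanes: a 2.3-fold lower number from compound 3 to compound 4 (0.36 log units; beyond the scatter) is a modest fall. The comparison with the other 3,3-dimethyloxetan-2-yl compound rests on a limit of the assay and gives only a floor: an at least 2.5-fold lower number from compound 2 to compound 4 (0.40 log units; beyond the scatter). Oxan-4-yl still does not reach the level of 4,4-dimethyloxetan-2-yl, with a 6.9-fold higher number from compound 1 to compound 4 (0.84 log units; beyond the scatter).

Open, going by these compounds, is how a cyclohexyl or piperidin-4-yl group would read at this place in this assay. Also open, on these data alone, is how the opposite ring configuration of 4,4-dimethyloxetan-2-yl would read.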